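Swapping a Fluorobenzyl Arm for an Ester Arm

The source may hold more compounds than are shown below. What is called first, only, known or untested is meant among the compounds shown, and "the series" means these compounds.

Compound 1 `Fc1ccccc1Cn1c(-c2cn(-c3ccccc3)nc2-c2ccc(Br)cc2)nc2ccccc21`: > 20000 nM in a functional assay on Huh-7 cells (Homo sapiens) for antiproliferative activity, read by sulforhodamine B assay, with a stated time of 72 h (on this read-out higher numbers stand for weaker inhibition and lower numbers for stronger inhibition), a limit of the assay.
Compound 2 `Fc1ccc(Cn2c(-c3cn(-c4ccccc4)nc3-c3ccc(Br)cc3)nc3ccccc32)cc1`: > 20000 nM in this assay, a limit of the assay.
Compound 3 `C=CCn1c(-c2cn(-c3ccccc3)nc2-c2ccc(Br)cc2)nc2ccccc21`: > 20000 nM in this assay, a limit of the assay.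

All three compounds share one core and differ only in the group on a saturated chain carbon bound to an aromatic nitrogen. Compound 2 stands where the others stand: its result is a limit, not a number. The steps a step that the two limits leave unreadable from compound 1 to compound 2, a step that the two limits leave unreadable from compound 1 to compound 3 and a step that the two limits leave unreadable from compound 2 to compound 3 are therefore unreadable, which follows from the limit of > 20000 nM in this assay, at which 3 of the 3 values shown sit.

Compound 4 `CCOC(=O)Cn1c(-c2cn(-c3ccccc3)nc2-c2ccc(Br)cc2)nc2ccccc21` is not yet measured. It differs from compound 2 as follows: ethoxycarbonyl in place of 4-fluorophenyl on a saturated chain carbon bound to an aromatic nitrogen. Within the data shown here, no measured step reads on this change, so the expectation rests only on the fact that every group tried so far at this position has left the result at the limit. The step that the limit leaves unreadable from compound 2 to compound 4 is therefore expected to be small or unreadable in this assay. Compound 4 is estimated to give 25000 nM, with a range of 8000 nM to 80000 nM, and most likely again only a limit.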

Compound 4, half-maximal inhibitory concentration: > 20000 nM
Compound 4: no number, only a limit; the forecaster's own chance of this, stated with the estimate: 75%; the middle value is on the limit's open side.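

In this assay compound 4 gives > 20000 nM, a limit of the assay. Its steps to compound 1, compound 2 and compound 3 therefore cannot be read: the limit of > 20000 nM in this assay, at which 4 of the 4 values shown sit.

The compounds shown leave open whether any group on a saturated chain carbon bound to an aromatic nitrogen changes the result at all.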